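A dichlorophenyl analogue of compound 1 awaits testing

The source may report more compounds than this note shows. Statements on the series, on what has been measured and on what is new or still open speak of the compounds shown alone.

Two compounds sharing one core were tested in a functional assay on CCRF-CEM cells (Homo sapiens) for cytotoxicity, read by sulforhodamine B assay, with a stated time of 48 h, tested at 0.1 uM; on this read-out lower numbers stand for a stronger effect and higher numbers for a weaker effect at the one concentration tested. Compound 1 `COc1cc(-c2cc(/C=C/C(=O)c3ccc(N)cc3)[nH]n2)cc(OC)c1OC` gives 91% in this assay, and compound 2 `COc1ccc(-c2cc(/C=C/C(=O)c3ccc(OC)c(OC)c3)[nH]n2)cc1` gives 97%, the two numbers lying within the scatter of each other, so compound 1 stands alongside compound 2 rather than apart from it. Compound 3 `COc1cc(-c2cc(/C=C/C(=O)c3ccc(Cl)c(Cl)c3)[nH]n2)cc(OC)c1OC` differs from compound 1 by 3,4-dichlorophenyl in place of 4-aminophenyl on a carbonyl carbon. Going by the values given here, no measured step between compounds that differ in one place is available here. With both measured values sitting near the top of the scale, compound 3 is expected to show a step from compound 1 that stays within the scatter, a number 3 percentage points lower from compound 1 to compound 3 (within the scatter). Compound 3 is therefore estimated at 88%, ranging from 72% to 100%.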

Compound 3, a percentage reported as activity, at one concentration (the size of the read-out at that concentration, not a potency): 98%
Compound 3: middle estimate off by 10 percentage points, on the low side, and the stated range covers the measured number.
By their numbers in this assay, from the lowest: compounds 1, 2 and 3 (each within the scatter of the next).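

Placing 3,4-dichlorophenyl on the carbonyl carbon in place of 4-aminophenyl gives a number 7 percentage points higher from compound 1 to compound 3 (within the scatter) in this assay and provides the first comparison of compounds that differ in one place. At this position, the exchange of one substituted phenyl for another, with the hydrogen-bond donor and acceptor of 4-aminophenyl gone, leaves the read-out unresolved from that of the parent compound. Nothing measured here offers an explanation for this result.

The compounds shown leave open whether a group other than a substituted phenyl, such as a carboxylic acid or a longer alkyl chain, would change the read-out at this carbonyl carbon. They also leave open how these compounds would behave at any other concentration.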